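This account rests on a few compounds, and the source may have more. Where it says the series, first, only, none or still open, it means among the compounds named here.

Compound 1 `CCC(CC)O[C@@H]1C=C(C(=O)O)C[C@H](NCc2ccc(SC(C)CC)cc2)[C@H]1NC(C)=O` and compound 3 `CCC(CC)O[C@@H]1C=C(C(=O)O)C[C@H](NCc2ccc(SC3CCCC3)cc2)[C@H]1NC(C)=O` share one core, while compound 2 `CCC(CC)O[C@@H]1C=C(C(=O)O)C[C@H](NCc2cccc(SC(C)CC)c2)[C@H]1NC(C)=O` is built from the same atoms as compound 1 joined differently; the difference between the two cores is not broken down here. In an ADME assay on cells (Fibroblast, Gallus gallus) for cytotoxicity, read by CCK-8 assay, with a stated time of 48 h (on this read-out lower numbers stand for higher toxicity in this test and higher numbers for lower toxicity in this test), compound 1 reaches only the limit of the test, > 200000 nM. Compound 2 likewise gives only a limit in this assay, > 200000 nM. Compound 3 also stops at a limit in this assay, > 200000 nM. The change from compound 1 to compound 3 is cyclopentyl in place of sec-butyl on a sulfur, and its step, a step that the two limits leave unreadable from compound 1 to compound 3, cannot be sized because of the limit of > 200000 nM in this assay, at which 3 of the 3 values shown sit. Compound 4 `CCC(CC)O[C@@H]1C=C(C(=O)O)C[C@H](NCc2cccc(SC3CCCC3)c2)[C@H]1NC(C)=O` differs from compound 2 by the same change, (cyclopentyl in place of sec-butyl on a sulfur). For compound 4 the expected step that the limit leaves unreadable from compound 2 to compound 4 rests on compound 1 and compound 3 both sitting at the limit of > 200000 nM in this assay, at which 3 of the 3 values shown sit. Compound 4 is therefore expected to give 300000 nM in this assay.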

Compound 4, half-maximal cytotoxic concentration: > 200000 nM
Compound 4: a limit, no number (the forecaster's own chance of this, stated with the estimate: 85%); the middle value is on the limit's open side.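

Compound 2 and compound 4 both stop at a limit, so no step can be read between them: the limit of > 200000 nM in this assay, at which 4 of the 4 values shown sit.

The compounds shown leave open at what concentration any of them would turn toxic in this assay, and whether sec-butyl and cyclopentyl would then differ.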